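Methyl removed from compound 2: what to expect

The source may hold more compounds than are shown below. What is called first, only, known or untested is meant among the compounds shown, and "the series" means these compounds.

Among the measured compounds shown here, compound 2 `COc1cc(-c2nn(-c3cccc(NC(=O)Nc4ccc(Cl)c(C(F)(F)F)c4)c3)cc2-c2ccncc2)ccc1Cl` is the only member with a number in a functional assay on HT-29 cells (Homo sapiens) for inhibition, read by sulforhodamine B assay, with a stated time of 48 h; on this read-out higher numbers stand for lower toxicity in this test and lower numbers for higher toxicity in this test; there compound 2 gives 21500 nM. Compound 1 `O=C(Nc1cccc(-n2cc(-c3ccncc3)c(-c3ccc(Cl)c(O)c3)n2)c1)Nc1ccc(Cl)c(Cl)c1` reaches only the limit of the assay, > 32500 nM, a limit and not a number. Compound 3 `O=C(Nc1cccc(-n2cc(-c3ccncc3)c(-c3ccc(Cl)c(O)c3)n2)c1)Nc1ccc(Cl)c(C(F)(F)F)c1` is compound 2 with hydrogen in place of methyl on an oxygen on an aromatic ring, reading methoxy to hydroxy. For the measured compounds named here, no measured pair isolates this change, though compound 1 also carries the hydroxy. The step of a 1.6-fold higher number from compound 2 to compound 3 (0.21 log units; within the scatter) is expected to be small, toward lower toxicity or none beyond the scatter. Compound 3 is accordingly expected near 35000 nM, between 14000 nM and 90000 nM.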

Compound 3, concentration lethal to 50% of the cells: 22600 nM
The estimate for compound 3 lay 1.5-fold (0.19 log units) above the measured number; low and high end bracket the measured number.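

Methoxy to hydroxy now stands as an isolated pair in this assay, with a 1.1-fold higher number from compound 2 to compound 3 (0.02 log units; within the scatter), so removing this methyl produces no readable change at this position. Trifluoromethyl in place of chloro on an aromatic carbon gives an at least 1.4-fold lower number from compound 1 to compound 3 (0.15 log units; that floor lies within the scatter), which does not establish a change beyond the scatter. Compound 1 carries a limit and not a number: the limit of > 32500 nM in this assay, at which 1 of the 3 values shown sits.

Going by these compounds, whether a longer chain on this oxygen, or an amine in place of the hydroxy, would shift the number in this assay remains open.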